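Ethynyl for iodo on the compound 3 scaffold

The source may report more compounds than this note shows. Statements on the series, on what has been measured and on what is new or still open speak of the compounds shown alone.

Values in a functional assay on HCT-116 cells (Homo sapiens) for cytotoxicity, with a stated time of 3 days (on this read-out higher numbers stand for weaker inhibition and lower numbers for stronger inhibition), follow
- compound 1 `C#Cc1nc(C(=O)Nc2ccc(Cl)cc2)cs1` gives 15900 nM as a number
- compound 2 `Cn1cnc2ccccc21` gives > 40000 nM as a limit
- compound 3 `Ic1nc2ccccc2o1` gives > 40000 nM as a limit

The value of compound 3 is a limit and not a number. Compound 3 stands on the limit of > 40000 nM in this assay, at which 2 of the 3 values shown sit, and has no exact position.

Compound 4 `C#Cc1nc2ccccc2o1` carries ethynyl in place of iodo on an aromatic carbon with the rest of the structure unchanged. For the measured compounds named here, no measured step shows what this exchange does in this assay so the expectation rests on one comparison. Going by the values given here, compound 1 is the only measured compound with an ethynyl group, and on a different core it gives 15900 nM as a number.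

A moderate move towards stronger inhibition is therefore expected, although a second limit remains possible. The estimated step runs an at least 2.6-fold lower number from compound 3 to compound 4 (0.42 log units; beyond the scatter) in that direction. For compound 4 the expected value is 15000 nM with an estimated range of 4000 nM to 40000 nM as the outer ends.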

Compound 4, half-maximal inhibitory concentration: 11600 nM
For compound 4 the middle estimate is 1.3-fold (0.11 log units) above the measured one, within the range that was stated.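

In this assay, for the compounds shown here, ethynyl in place of iodo on the aromatic carbon next to the ring nitrogen and next to the ring oxygen gives an at least 3.4-fold lower number from compound 3 to compound 4 (0.53 log units; beyond the scatter), the only step that isolates a change at this position. It shows that ethynyl brings this scaffold to a measurable value, which compound 1 could not show on its different core. Compound 3 stands on a limit and not on a number, so the step gives only a lower bound on the size of the change: the limit of > 40000 nM in this assay, at which 2 of the 4 values shown sit.

The compounds shown leave open whether this shift is particular to ethynyl or would also follow from a nitrile or an amine on the same carbon. They also leave open whether ethynyl has a comparable effect on the core of compound 1, which has no matching partner here.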